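The source may report more compounds than this note shows. Statements on the series, on what has been measured and on what is new or still open speak of the compounds shown alone.

Compound 1 `Cc1ccc(C2=NOC(c3ccccc3)O2)cc1` shares its core with compound 2 `Cc1ccc(C2=NOC(c3ccccc3O)O2)cc1` and compound 3 `COc1ccc(C2ON=C(c3ccc(C)cc3)O2)cc1`. In an ADME assay on Vero cells (Chlorocebus sabaeus) for cytotoxicity, read by sulforhodamine B assay, with a stated time of 72 h (on this read-out higher numbers stand for weaker inhibition and lower numbers for stronger inhibition), compound 1 gives "not determined" (no result reported), so no single number places it on this scale. In this assay compound 2 likewise gives "not determined" (no result reported). Among the measured compounds shown here, for compound 3 in this assay only a limit of the assay is reported, > 180000 nM, and the sole value shown is thus the limit of > 180000 nM in this assay, at which 1 of the 3 values shown sits, rather than a measured figure. Compound 4 `Cc1ccc(C2=NOC(C)(c3ccccc3)O2)cc1` differs from compound 1 by methyl in place of hydrogen on a saturated ring carbon. For the measured compounds named here, no step between measured compounds is available, so this change is expected to bring no difference beyond the usual scatter of this assay, with a limit again likely. Compound 4 is therefore estimated at 150000 nM in this assay, within a range from 40000 nM to 500000 nM.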

Compound 4, half-maximal inhibitory concentration: > 180000 nM
Compound 4: no number, only a limit; the forecaster's own chance of this, stated with the estimate: 70%; middle value at least 1.2-fold (0.07 log units) from the limit.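

Compound 1 has no number and compound 4 only a limit, so no step can be read between them. The compounds shown leave open whether methyl in place of hydrogen changes anything in this assay.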